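The compounds below may be only part of what the source reports. "The series", "measured", "known", "first", "only" and "open" are said of these compounds alone.

Working notes on the series.

Compound 1 `C[C@H](NC(=O)c1cc(C(F)(F)F)ccc1Oc1ccccc1)c1cccc(S(C)(=O)=O)c1` gives 57000 nM in a physicochemical assay for solubility, measured as kinetic solubility; on this read-out lower numbers stand for lower solubility and higher numbers for higher solubility. Compound 2 `CS(=O)(=O)c1cccc([C@H](CO)NC(=O)c2cc(C(F)(F)F)ccc2Oc2ccccc2)c1` gives 11000 nM in this assay. The change from compound 1 to compound 2, (hydroxy in place of hydrogen on a saturated chain carbon, two bonds along the chain from an amide-type nitrogen and an aromatic carbon), made the step of a 5.2-fold lower number from compound 1 to compound 2 (0.71 log units; beyond the scatter).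

Compound 3 `C[C@H](NC(=O)[C@H]1CCCC[C@@H]1c1ccccc1)c1ccccc1` gives 57000 nM in this assay, level with compound 1 at the digits read, so the two stand together at the top of the three measured numbers. The difference between the core of compound 3 and the core of compound 1 is not broken down here.

Compound 4 `O=C(N[C@@H](CO)c1ccccc1)[C@H]1CCCC[C@@H]1c1ccccc1` is not yet measured. Among the compounds with values here, it differs from compound 3 by hydroxy in place of hydrogen on a saturated chain carbon, two bonds along the chain from an amide-type nitrogen and an aromatic carbon, which is the same change as the one from compound 1 to compound 2, at a place described in the same words, on a different core.

Within the data shown here, the expected step is a 4.4-fold lower number from compound 3 to compound 4 (0.64 log units; beyond the scatter), resting on the single earlier occurrence of the change, a 5.2-fold lower number from compound 1 to compound 2 (0.71 log units; beyond the scatter); with only one prior example and an unrelated core, the range is kept wide. The estimate for compound 4 is 13000 nM, within 4000 nM to 45000 nM.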

Compound 4, solubility: 455000 nM
For compound 4 the middle estimate is 35-fold (1.54 log units) below the measured one; the measured number lies above the stated range.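

On the core of compound 3, hydroxy in place of hydrogen on a saturated chain carbon, two bonds along the chain from an amide-type nitrogen and an aromatic carbon, gives a higher number in this assay (an 8.0-fold higher number from compound 3 to compound 4 (0.90 log units; beyond the scatter)), while the same change on the core of compound 1 gives a lower one (a 5.2-fold lower number from compound 1 to compound 2 (0.71 log units; beyond the scatter)), and both steps lie beyond the scatter. In these two pairs, neither the direction nor the size of the step carries from one core to the other, but two pairs cannot show how the change behaves on any further core or which of the two outcomes is more typical of the series. Nothing available bears on why the two steps part.

Going by these compounds, the difference between the two cores is not broken down, so it remains open which part of it goes with the reversal. On these data alone, it is also open whether an amine or a carboxylic acid in place of the hydroxy would follow either pair.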